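This account rests on a few compounds, and the source may have more. Where it says the series, first, only, none or still open, it means among the compounds named here.

Measured in a functional assay on LS174T cells (Homo sapiens) for cytotoxicity; a higher number here means a weaker inhibitor, a lower number a stronger inhibitor:
- compound 1 `Nc1cccc(SC(=O)NC(CCC(=O)O)C(=O)O)c1`: > 5000000 nM
- compound 2 `COc1ccc(SC(=O)N[C@H](CCC(=O)O)C(=O)O)cc1`: > 500000 nM

Compound 1 stands at > 5000000 nM, which is a limit of this assay, not a number. On these data alone, for compound 2, > 500000 nM is likewise only a limit, so its true position is unknown. Compound 3 `COc1ccc(SC(=O)N[C@@H](CCC(=O)O)C(=O)O)cc1` is its mirror-image partner at one centre (the two compounds have the same atoms and bonds and differ only in configuration as drawn: 1 of 1 stereo elements differ; a stereocentre at a saturated chain carbon is drawn R in compound 2 and S in compound 3): a stereocentre at a saturated chain carbon is drawn R in compound 2 and S in compound 3. Among the measured compounds shown here, no measured pair shows what such a change does, so only a small change in this assay, within the usual scatter and in no particular direction, is expected: a number no higher from compound 2 to compound 3 (the limit leaves the size open). For compound 3 the estimated value is 500000 nM, with an expected range of 200000 nM to 1000000 nM.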

Compound 3, half-maximal inhibitory concentration: > 500000 nM
Compound 3 ended at the assay's limit; the forecaster's own chance of this, stated with the estimate: 75%; the middle value sits exactly at the limit.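

Compound 2 and compound 3 each give only a limit, so the step between these mirror-image partners cannot be read: the limit of > 500000 nM in this assay, at which 2 of the 3 values shown sit.

On these data alone, whether the configuration at that stereocentre makes any difference stays open, as do the true values behind these limits.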